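Nitro for methylsulfanyl on the shared core

A few compounds are considered here, and "the series" means these few. Any claim that something is new, unique, unknown or untested is made for them only; others in the source may bear on it.

Measured so far:
compound 1, `COc1cc(C(=O)/C=C/c2cn(C)c3ccccc23)cc(SC)c1OC`: 105 nM
compound 2, `COc1cc(C(=O)/C(C)=C/c2c[nH]c3ccccc23)cc([Se]C)c1OC`: 34 nM

Two compounds carry numbers in a functional assay on HeLa cells (Homo sapiens) for antiproliferative activity, read by MTT assay, with a stated time of 48 h; a higher number here means a weaker inhibitor, a lower number a stronger inhibitor. Compound 1 gives 105 nM and stands highest of the two. Compound 2 gives 34 nM, a lower number beyond the usual scatter; the two structures differ in several places at once, so the gap cannot be tied to any single change.

Compound 3, `COc1cc(C(=O)/C=C/c2cn(C)c3ccccc23)cc([N+](=O)[O-])c1OC`, awaits measurement in this assay. It differs from compound 1 in one place: nitro in place of methylsulfanyl on an aromatic carbon. Going by the values given here, no pair among the measured compounds shows this exchange, so no measured step is available to anchor the expectation, and the series so far offers no pattern for what enters.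

The step of a 1.4-fold higher number from compound 1 to compound 3 (0.15 log units; within the scatter) is therefore expected to be modest, not clearly beyond the scatter, with no firm direction assigned. For compound 3 the expected value is 150 nM, with a range from 50 nM to 450 nM; the measured number will show whether the exchange leaves the series where compound 1 stands.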

Compound 3, half-maximal inhibitory concentration: 1960 nM
The estimate for compound 3 lay 13-fold (1.12 log units) below the measured number; the whole stated range lies below it.
By their numbers in this assay, from the lowest: compound 2; then compound 1; then compound 3.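

In this assay, going by these compounds alone, the aromatic carbon ortho to a methoxy group and meta to a large group proves sensitive to what it carries: nitro in place of methylsulfanyl gives a 19-fold higher number from compound 1 to compound 3 (1.27 log units; beyond the scatter) and so provides the first single-place comparison, with a large step beyond the scatter. The counts that separate the two groups are small, with methylsulfanyl at 2 heavy atoms and 1 hydrogen-bond acceptor and nitro at 3 heavy atoms and 2 hydrogen-bond acceptors, and neither group has a ring or a net charge. No measurement at hand identifies which difference between the two groups lies behind this step.

From the compounds shown here alone, whether an amine, a hydroxyl group or a longer chain at this position would stay close to compound 1 at 105 nM or move toward compound 3 at 1960 nM remains open. Also open, going by these compounds, is whether the same exchange would produce a step of similar size on the core of compound 2, which differs from compound 1 in several places.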